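The compounds below may be only part of what the source reports. "The series", "measured", "known", "first", "only" and "open" are said of these compounds alone.

Working notes on the series, read in a toxicity assay on microsomes from liver (Homo sapiens) for metabolic stability, read by LC-MS, using NADPH, tested at 1 uM; on this read-out lower numbers stand for slow clearance and higher numbers for fast clearance. Compound 1 `COc1ncc(-c2nc(C(F)(F)F)sc2N2CCN(C(=O)Cn3nc(C)nc3C)[C@H](C)C2)cn1` reads < 10 mL.min-1.g-1 and this is a limit of the assay, not a number. Compound 2 `Cc1nc(C)n(CC(=O)N2CCN(c3sc(C(F)(F)F)nc3-c3cnc(OC(C)C)nc3)C[C@H]2C)n1` gives 16 mL.min-1.g-1 in this assay as a measured number. Compound 3 `CCc1ncc(-c2nc(C(F)(F)F)sc2N2CCN(C(=O)Cn3nc(C)nc3C)[C@H](C)C2)cn1` gives 43 mL.min-1.g-1 as the higher of the two measured numbers.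

Compound 4 `CCCc1ncc(-c2nc(C(F)(F)F)sc2N2CCN(C(=O)Cn3nc(C)nc3C)[C@H](C)C2)cn1` turns 2-ethylpyrimidin-5-yl into 2-propylpyrimidin-5-yl: methyl in place of hydrogen on a saturated chain carbon, two bonds along the chain from an aromatic carbon.

Among the measured compounds shown here, no measured step makes this exact change. The nearest is an at least 1.6-fold higher number from compound 1 to compound 2 (0.20 log units; that floor lies within the scatter), where isopropyl replaces methyl on an oxygen and the floor stays within the scatter. The steps of an at least 4.3-fold higher number from compound 1 to compound 3 (0.63 log units; beyond the scatter) and a 2.7-fold higher number from compound 2 to compound 3 (0.43 log units; beyond the scatter) are larger, but both swap an oxygen-linked group for ethyl and so bear only loosely.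

A small rise in the number is expected, probably within the scatter. The expected step is a 1.4-fold higher number from compound 3 to compound 4 (0.14 log units; within the scatter) on this estimate. For compound 4 the estimate is 60 mL.min-1.g-1 with an expected range from 30 mL.min-1.g-1 to 120 mL.min-1.g-1 in this assay.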

Compound 4, intrinsic clearance in microsomes: 80 mL.min-1.g-1
Compound 4: middle estimate off by 1.3-fold (0.12 log units), on the low side; the measured number falls inside the stated range.
By their numbers in this assay, from the lowest: compound 2; then compounds 3 and 4 (each within the scatter of the next). At a limit, below all of these: compound 1.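

In this assay, among the compounds shown here, the first change confined to the saturated chain gives a 1.9-fold higher number from compound 3 to compound 4 (0.27 log units; within the scatter), so adding this methyl to 2-ethylpyrimidin-5-yl to give 2-propylpyrimidin-5-yl does not separate the two compounds beyond the scatter. Propyl in place of isopropoxy gives a 5.0-fold higher number from compound 2 to compound 4 (0.70 log units; beyond the scatter), a wider gap than the ethyl compound showed against the same oxygen-linked group, although the ethyl and propyl compounds themselves cannot be told apart. Propyl in place of methoxy gives an at least 8.0-fold higher number from compound 1 to compound 4 (0.90 log units; beyond the scatter), which is only a floor set by a limit of the assay: the limit of < 10 mL.min-1.g-1 in this assay, at which 1 of the 4 values shown sits.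

The compounds shown leave open how a butyl chain, or a hydroxyl at the end of the propyl chain, would read in this assay. They also leave open whether an amine on this aromatic carbon would read nearer compound 2.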